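Second ring fluoro on the benzyl triazolethiol series

The compounds below may be only part of what the source reports. "The series", "measured", "known", "first", "only" and "open" are said of these compounds alone.

Among the measured compounds shown here, compound 2 `Fc1cccc(Cn2cnnc2S)c1` holds the lowest of the two numbers measured so far in an assay on isolated protein for inhibition of Dopamine beta-hydroxylase (Bos taurus); a higher number here means a weaker inhibitor, a lower number a stronger inhibitor: compound 2 gives 1900 nM. For the measured compounds named here, its nearest neighbour is compound 1 `Sc1nncn1Cc1ccccc1`, which in this assay gives 24000 nM; the single step between them is a 13-fold lower number from compound 1 to compound 2 (1.10 log units; beyond the scatter). Compound 3 `Fc1cc(F)cc(Cn2cnnc2S)c1` differs from compound 2 by fluoro in place of hydrogen on an aromatic carbon. Going by the values given here, the only measured step that bears on this change is the one from compound 1 to compound 2, and it was large. A second fluoro on the same ring is not the same change as the first, and whether that step repeats cannot be read from one pair; a further lowering of the number, smaller than before, is the working expectation, though a step within the scatter is also possible. Compound 3 is therefore expected at 900 nM (range 300 nM to 3000 nM), an expected step of a 2.1-fold lower number from compound 2 to compound 3 (0.32 log units; beyond the scatter).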

Compound 3, half-maximal inhibitory concentration: 1000 nM
For compound 3 the middle estimate is 1.1-fold (0.05 log units) below the measured one, within the range that was stated.
By their numbers in this assay, from the lowest: compounds 3 and 2 (each within the scatter of the next); then compound 1.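

In this assay, a second fluoro on an aromatic carbon meta to a fluoro group gives a step that stays within the scatter (a 1.9-fold lower number from compound 2 to compound 3 (0.28 log units; within the scatter)), so compound 2 and compound 3 cannot be told apart on this read-out. Among the compounds shown here, the first fluoro gave a step beyond the scatter (a 13-fold lower number from compound 1 to compound 2 (1.10 log units; beyond the scatter)), and that size of step does not recur with the second fluoro in this one pair. No measurement shown accounts for the difference between the two steps.

From the compounds shown here alone, whether a chloro, a methoxy group or an amine at this same ring carbon would also stay within the scatter of compound 2 remains open. So does the effect on the number of a longer chain in place of the benzyl methylene.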